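The source may report more compounds than this note shows. Statements on the series, on what has been measured and on what is new or still open speak of the compounds shown alone.

Measured so far in a functional assay on UACC-62 cells (Homo sapiens) for inhibition, read by sulforhodamine B assay, with a stated time of 48 h; on this read-out higher numbers stand for weaker inhibition of growth and lower numbers for stronger inhibition of growth
- compound 1 `COc1ccc(/C=C/C2(C)C=CC(=O)O2)cc1OC` gives 84100 nM
- compound 2 `COc1ccc(/C=C/C2(C)C=CC(=O)O2)c(OC)c1OC` gives 71500 nM

Compound 2 cannot be separated from compound 1 on these numbers, the step being a 1.2-fold lower number from compound 1 to compound 2 (0.07 log units; within the scatter). Compound 3 `COc1c(O)ccc(/C=C/C2(C)C=CC(=O)O2)c1OC` departs from compound 2 by hydrogen in place of methyl on an oxygen on an aromatic ring, or methoxy to hydroxy. Going by the values given here, no measured step makes this exchange. The only one available, methoxy in place of hydrogen on an aromatic carbon, is a 1.2-fold lower number from compound 1 to compound 2 (0.07 log units; within the scatter) and bears on it only loosely. On that thin evidence, no shift beyond the scatter is expected in this assay, and neither direction is favoured. The expected step is a 1.1-fold lower number from compound 2 to compound 3 (0.04 log units; within the scatter). For compound 3 the estimated value is 65000 nM, with an expected range of 25000 nM to 130000 nM.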

Compound 3, concentration for total growth inhibition: 24600 nM
The estimate for compound 3 lay 2.6-fold (0.42 log units) above the measured number; measured number outside the range, below it.
By their numbers in this assay, from the lowest: compound 3; then compounds 2 and 1 (each within the scatter of the next).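

In this assay, going by these compounds alone, hydrogen in place of methyl on an oxygen on an aromatic ring gives a 2.9-fold lower number from compound 2 to compound 3 (0.46 log units; beyond the scatter), a modest step and the first single change to pass the scatter. The earlier exchange, methoxy in place of hydrogen on an aromatic carbon, gave a 1.2-fold lower number from compound 1 to compound 2 (0.07 log units; within the scatter), so growth inhibition on this read-out responds to methoxy to hydroxy at this oxygen in a way that step did not show. Nothing available explains the shift.

As far as these compounds go, it remains open whether the lower number depends on the hydroxy itself or only on the loss of the methyl; an amine or an ethoxy group at this place would help separate the two. Also open, from the compounds shown here alone, is whether methoxy to hydroxy at either remaining methoxy group of compound 3 would give a comparable step.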